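The source may report more compounds than this note shows. Statements on the series, on what has been measured and on what is new or still open speak of the compounds shown alone.

Measured so far in a functional assay on HL-60 cells (Homo sapiens) for antiproliferative activity, read by MTT assay, with a stated time of 48 h; on this read-out lower numbers stand for stronger inhibition and higher numbers for weaker inhibition:

- compound 1, `CNC1=C(Cl)C(=O)c2ncccc2C1=O`: 2450 nM
- compound 2, `NC1=C(Cl)C(=O)c2ncccc2C1=O`: 3260 nM
- compound 3, `CS(=O)(=O)C1=C(N)C(=O)c2cccnc2C1=O`: 4530 nM

Compound 1 gives the lowest of the three numbers, but its gaps to the others stay inside the usual scatter: a 1.3-fold higher number from compound 1 to compound 2 (0.12 log units; within the scatter), and the values of compound 1 and compound 3 likewise lie within the scatter of each other, so no order among the three can be read from this set.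

Compound 4, `CNC1=C([S+](C)[O-])C(=O)c2ncccc2C1=O`, has not been measured. It differs from compound 1 by a group of 3 heavy atoms (1 carbon, 1 oxygen, 1 sulfur; no ring) in place of one chlorine atom, on a double-bonded ring carbon; the methylamino group of compound 1 is kept.

Among the compounds with values here, two measured steps bear on this change. The swap of the ring chlorine for a sulfur-bearing group is seen once, in compound 2 to compound 3, where methylsulfonyl entered in place of chloro: a 1.4-fold higher number from compound 2 to compound 3 (0.14 log units; within the scatter). Within the data shown here, the methyl on the amine nitrogen, the one point where compound 4 and compound 3 differ apart from the sulfur-bearing group itself, is covered by a 1.3-fold higher number from compound 1 to compound 2 (0.12 log units; within the scatter). Neither step left the scatter, so the expectation for compound 4 in this assay is a small move upward at most, a 1.2-fold higher number from compound 1 to compound 4 (0.09 log units; within the scatter).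

Compound 4 is therefore estimated at 3000 nM in this assay, with a plausible range from 1200 nM to 8000 nM.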

Compound 4, half-maximal inhibitory concentration: 12100 nM
Compound 4: middle estimate off by 4.0-fold (0.61 log units), on the low side, and the stated range ends below it.
By their numbers in this assay, from the lowest: compounds 1, 2 and 3 (each within the scatter of the next); then compound 4.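

In this assay, within the data shown here, the change from chloro to the sulfur-bearing group of 3 heavy atoms, on a double-bonded ring carbon next to the ring atom that bears a methylamino group, gives a 4.9-fold higher number from compound 1 to compound 4 (0.69 log units; beyond the scatter), the only step in this set beyond the scatter. The number at this position therefore does respond to the group it carries, which the earlier swap of chloro for methylsulfonyl, a 1.4-fold higher number from compound 2 to compound 3 (0.14 log units; within the scatter), did not show, so replacing chloro with a sulfur-bearing group has no single outcome across compounds 2, 3, 1 and 4. The data shown offer no measurement that explains the rise in compound 4.

Whether this rise depends on the methylamino group remains open, since the same sulfur-bearing group is shown only with that neighbour and no step isolates the pairing. Also open, going by these compounds, is how this position responds to groups of other kinds in place of chloro, such as a methylthio group, a dimethylamino group or a carboxylic acid, and whether any of them gives a number beyond the scatter in either direction from compound 1.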